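The source may report more compounds than this note shows. Statements on the series, on what has been measured and on what is new or still open speak of the compounds shown alone.

Compound 1 `COc1cccc(CCC(=O)Nc2nc3ccccc3c(=O)s2)c1` gives 621 nM in an assay on mitochondria (strain Sprague-Dawley) for inhibition of Amine oxidase [flavin-containing] B (Rattus norvegicus), read by fluorescence and Amplex Red, with stated times of 30 min and 45 min; a lower number here means a stronger inhibitor, a higher number a weaker inhibitor. Compound 2 `O=C(CCCc1cccc(Cl)c1)Nc1nc2ccccc2c(=O)s1` gives 6880 nM in this assay, a step of an 11-fold higher number from compound 1 to compound 2 (1.04 log units; beyond the scatter). For compound 3 `O=C(CCc1ccc(Cl)c(Cl)c1)Nc1nc2ccccc2c(=O)s1` this assay reports only a limit, > 10000 nM. Compound 3 therefore stands at the limit of > 10000 nM in this assay, at which 1 of the 3 values shown sits. From compound 1 the step is an at least 16-fold higher number from compound 1 to compound 3 (1.20 log units; beyond the scatter), and from compound 2 it is an at least 1.4-fold higher number from compound 2 to compound 3 (0.16 log units; that floor lies within the scatter). Compound 4 `O=C(CCc1ccccc1Br)Nc1nc2ccccc2c(=O)s1` differs from compound 3 by 2-bromophenyl in place of 3,4-dichlorophenyl on a saturated chain carbon, two bonds along the chain from a carbonyl carbon. Both halogen-bearing aryl replacements from compound 1 raised the number strongly, an 11-fold higher number from compound 1 to compound 2 (1.04 log units; beyond the scatter) and an at least 16-fold higher number from compound 1 to compound 3 (1.20 log units; beyond the scatter), and compound 4 again carries a halogen on the ring. Compound 4 is expected to stay weak, with an estimated step of an at least 1.2-fold lower number from compound 3 to compound 4 (0.09 log units; that floor lies within the scatter) that lies within the scatter. The estimate for compound 4 is 8000 nM, in a range from 2000 nM to 30000 nM.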

Compound 4, half-maximal inhibitory concentration: 64 nM
Estimate against measurement, compound 4: 130-fold (2.10 log units) above; the whole stated range lies above it.
By their numbers in this assay, from the lowest: compound 4; then compound 1; then compound 2. At a limit, above all of these: compound 3.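

In this assay a halogen on the ring is no bar to potency at this saturated chain carbon: 2-bromophenyl gives a 9.7-fold lower number from compound 1 to compound 4 (0.99 log units; beyond the scatter) and a 110-fold lower number from compound 2 to compound 4 (2.03 log units; beyond the scatter) and makes compound 4 the strongest of the four. Against 3,4-dichlorophenyl the change gives an at least 150-fold lower number from compound 3 to compound 4 (2.19 log units; beyond the scatter), so the outcome depends on which halogen pattern the ring carries, not on the presence of halogen alone. Compound 3 is held only as a limit: the limit of > 10000 nM in this assay, at which 1 of the 4 values shown sits.

From the compounds shown here alone, whether the gain belongs to bromine itself or to its place on the ring stays open. 2-Chlorophenyl and unsubstituted phenyl on the same chain would separate the two.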